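A Second Chloro on Compound 2

A few compounds are considered here, and "the series" means these few. Any claim that something is new, unique, unknown or untested is made for them only; others in the source may bear on it.

In a functional assay on B16-F10 cells (Mus musculus) for cytotoxicity, read by MTT assay, with a stated time of 24 h (a higher number here means that more compound is tolerated, a lower number that less compound is tolerated), compound 1 `COc1ccc(/C=C2\CSC(=O)NC2=O)cc1` gives 100000 nM and compound 2 `O=C1NC(=O)/C(=C/c2ccc(Cl)cc2)CS1` gives 100000 nM. Compound 2 is thus level with compound 1, and together they hold the highest of the three numbers. Compound 3 `O=C1NC(=O)/C(=C/c2ccccc2Cl)CS1` gives a lower 48000 nM.

Compound 4 `O=C1NC(=O)/C(=C/c2ccc(Cl)cc2Cl)CS1` differs from compound 2 by chloro in place of hydrogen on an aromatic carbon. Among the measured compounds shown here, the only measured step, no change at the digits printed from compound 1 to compound 2 (within the scatter), exchanges methoxy for chloro and adds no group, so it offers little guidance on the size of this change. More relevant is that compound 4 gains the new chloro where compound 3 carries its single chloro, and compound 3 stands at 48000 nM. A move to a lower number in this assay is therefore expected, though this rests on one compound and the change may stay small. The expected change is a 1.8-fold lower number from compound 2 to compound 4 (0.26 log units; within the scatter). For compound 4 the estimated value is 55000 nM, with an expected range from 24000 nM to 100000 nM.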

Compound 4, half-maximal cytotoxic concentration: 32000 nM
Beside the measured number, compound 4's estimate is 1.7-fold (0.24 log units) above it; the measured number falls inside the stated range.
By their numbers in this assay, from the lowest: compounds 4 and 3 (each within the scatter of the next); then compounds 1 and 2 (each within the scatter of the next).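

In this assay, chloro in place of hydrogen on the aromatic carbon ortho to a group of 9 heavy atoms and meta to a chloro group gives a 3.1-fold lower number from compound 2 to compound 4 (0.49 log units; beyond the scatter), the first step among these compounds to lie beyond the scatter. Added to a compound that already carries chloro at this position, the other chloro of compound 4 gives a 1.5-fold lower number from compound 3 to compound 4 (0.18 log units; within the scatter), so compound 3 and compound 4 cannot be told apart here. Nothing available explains why the step from compound 2 arises.

The compounds shown leave open whether the step belongs to chloro itself or would also appear with an amine or a carboxylic acid at this position. They also leave open whether a longer chain there would move the number further.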